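The source may report more compounds than this note shows. Statements on the series, on what has been measured and on what is new or still open speak of the compounds shown alone.

Among the measured compounds shown here, in a functional assay on DU-145 cells (Homo sapiens) for inhibition, read by trypan blue exclusion, with a stated time of 96 h (a lower number here means a stronger inhibitor of growth, a higher number a weaker inhibitor of growth), only two compounds have numbers so far. Compound 1 (`Cc1ccsc1/C=C(/SCc1ccccc1F)C(=O)c1ccc(Cl)cc1`) gives 50000 nM, and compound 2 (`Cc1ccc(CS/C(=C/c2ccc(Br)cc2)C(=O)c2ccc(Cl)cc2)cc1`) gives 10000 nM. Compound 2 thus holds the lower of the two numbers, and its gap to compound 1 lies beyond the usual scatter.

Compound 3 (`Cc1ccc(CS/C(=C/c2sccc2C)C(=O)c2ccc(Cl)cc2)cc1`) has not yet been measured in this assay. Relative to compound 2, it changes one group, with 3-methylthiophen-2-yl in place of 4-bromophenyl on a double-bonded chain carbon bound to a double-bonded chain carbon. For the measured compounds named here, no measured step isolates this exchange, so the forecast rests on thin evidence. The entering 3-methylthiophen-2-yl group also stands in compound 1, which gives 50000 nM, the higher of the two numbers. That single compound is slender support, but it points towards weaker growth inhibition rather than stronger. A modest rise in the number is therefore expected, estimated as a 2.0-fold higher number from compound 2 to compound 3 (0.30 log units; within the scatter). Compound 3 is estimated at 20000 nM, with an expected range from 7000 nM to 50000 nM.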

Compound 3, concentration for 50% growth inhibition: 10000 nM
Estimate against measurement, compound 3: 2.0-fold (0.30 log units) above; measured number inside the range.
By their numbers in this assay, from the lowest: compounds 2 and 3 (each within the scatter of the next); then compound 1.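

In this assay, the exchange of 4-bromophenyl for 3-methylthiophen-2-yl on a double-bonded chain carbon bound to a double-bonded chain carbon gives no change at the digits printed from compound 2 to compound 3 (within the scatter), so this one pair shows the two aromatic groups reading alike at this position, with 4-methylphenyl on the saturated chain carbon bound to a sulfur. The higher number of compound 1 can therefore no longer be read as a mark of the 3-methylthiophen-2-yl group, since compound 3 carries that group too, and the step with 4-methylphenyl in place of 2-fluorophenyl on a saturated chain carbon bound to a sulfur gives a 5.0-fold lower number from compound 1 to compound 3 (0.70 log units; beyond the scatter), which places the gap at that other position. Nothing at hand accounts for either step.

The compounds shown leave open whether this position would read the same with a group that has no aromatic ring, such as a longer chain or an amine. Among the compounds shown here, they also leave open whether the exchange at the double-bonded chain carbon would again read flat with 2-fluorophenyl on the saturated chain carbon, as only one such pair can be compared.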